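Exocyclic double-bond geometry in the hydrazone carboxylic acid series

The source may hold more compounds than are shown below. What is called first, only, known or untested is meant among the compounds shown, and "the series" means these compounds.

Compound 2 `O=C(O)CCC/C=C1/C[C@H]2C[C@@H](O)[C@H](/C=N/NC(=O)Nc3ccccc3)[C@H]2C1` stands second highest of the three numbers available in a functional assay on a cell-free system (plasma) for agonist activity at thromboxane A2 receptor (Homo sapiens) (a higher number here means a weaker inhibitor, a lower number a stronger inhibitor), where compound 2 gives 100 nM. Its nearest neighbour is compound 1 `O=C(O)CCC/C=C1/C[C@H]2C[C@@H](O)[C@H](/C=N/NC(=O)Nc3ccc([N+](=O)[O-])cc3)[C@H]2C1`, which in this assay gives 50 nM; the step of a 2.0-fold higher number from compound 1 to compound 2 (0.30 log units; within the scatter) is within the scatter. For the measured compounds named here, the furthest is compound 3 `O=C(O)CCC/C=C1\C[C@H]2CC[C@H](/C=N/NC(=O)Nc3ccc(Cl)c(Cl)c3)[C@H]2C1`, which in this assay gives 9000 nM; no single-change step links compound 3 to compound 2, so the two values can only be set side by side.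

Compound 4 `O=C(O)CCC/C=C1\C[C@H]2C[C@@H](O)[C@H](/C=N/NC(=O)Nc3ccccc3)[C@H]2C1` differs from compound 2 as follows: the two compounds have the same atoms and bonds and differ only in configuration as drawn: 1 of 6 stereo elements differ; a double bond is drawn Z in compound 2 and E in compound 4. Going by the values given here, no measured pair isolates this change. Among the compounds with values here, the only measured compound drawn with the same geometry as compound 4 is compound 3, and it also lacks the hydroxyl and carries two chlorines, so its weaker number cannot be assigned to the geometry alone. The expectation for compound 4 is therefore a modest loss, a 4.0-fold higher number from compound 2 to compound 4 (0.60 log units; beyond the scatter), with a wide range to cover both outcomes. Compound 4 is estimated at 400 nM in this assay, between 60 nM and 3000 nM.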

Compound 4, half-maximal inhibitory concentration: 1700 nM
Beside the measured number, compound 4's estimate is 4.3-fold (0.63 log units) below it, and the stated range covers the measured number.
By their numbers in this assay, from the lowest: compounds 1 and 2 (each within the scatter of the next); then compound 4; then compound 3.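

The exocyclic double bond now has a measured pair of its own: in this assay the change from Z to E as drawn gives a 17-fold higher number from compound 2 to compound 4 (1.23 log units; beyond the scatter) and is a large step. For the compounds shown here, the earlier compounds could not show this, since their only step was hydrogen in place of nitro on an aromatic carbon, which lies within the scatter. The loss at this position can be assigned to the double-bond geometry alone, with no other change to share it: the fact that compounds 2 and 4 differ only in the configuration as drawn

Going by these compounds, whether a step of this size holds with nitro on the aromatic ring, or without the hydroxyl, remains open. Also open, on these data alone, is how the same change in geometry reads with a tetrazole in place of the carboxylic acid or with a longer chain carrying the acid.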